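This account rests on a few compounds, and the source may have more. Where it says the series, first, only, none or still open, it means among the compounds named here.

The measured compounds in a functional assay on HCT-116 cells (Homo sapiens) for cytotoxicity, read by MTT assay, with a stated time of 48 h; a higher number here means a weaker inhibitor, a lower number a stronger inhibitor:

Compound 1, `O=C(/C=C/c1ccc2c(c1)B(O)OC2)c1cccnc1`: compound 1 gives 20500 nM.
Compound 2, `Cn1cccc1C(=O)/C=C/c1ccc2c(c1)B(O)OC2`: compound 2 reaches only the limit of the assay, > 100000 nM.
Compound 3, `O=C(/C=C/c1ccc2c(c1)B(O)OC2)c1ccc(Br)cc1`: compound 3 gives 9900 nM.

Compound 3 holds the lowest of the two numbers in this assay, with compound 1 as the nearest. Both measured steps change the whole aryl group on the carbonyl carbon: one gave a 2.1-fold lower number from compound 1 to compound 3 (0.32 log units; beyond the scatter), the other at least 10-fold lower number from compound 2 to compound 3 (1.00 log units; beyond the scatter), the second resting on (the limit of > 100000 nM in this assay, at which 1 of the 3 values shown sits). They show that the identity of this aryl group moves the number, but neither changes a substituent on an aryl ring that stays in place.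

Compound 4, `O=C(/C=C/c1ccc2c(c1)B(O)OC2)c1ccc([N+](=O)[O-])cc1`, differs from compound 3 by nitro in place of bromo on an aromatic carbon. Among the compounds with values here, no measured step matches this kind of change, so there is no direct precedent, and only a small movement is expected. Compound 4 is expected to give 8000 nM, within 3000 nM to 25000 nM. This estimate means an expected 1.2-fold lower number from compound 3 to compound 4 (0.09 log units; within the scatter), inside or close to the scatter.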

Compound 4, half-maximal inhibitory concentration: 9100 nM
For compound 4 the middle estimate is 1.1-fold (0.06 log units) below the measured one; the range from low to high includes it.
By their numbers in this assay, from the lowest: compounds 4 and 3 (each within the scatter of the next); then compound 1. At a limit, above all of these: compound 2.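

In this assay, within the data shown here, exchanging bromo for nitro on an aromatic carbon para to a large group is the first change of a substituent on an aryl ring that stays in place, and it gives a 1.1-fold lower number from compound 3 to compound 4 (0.04 log units; within the scatter), so the two compounds cannot be told apart here. Replacing the whole aryl group on the carbonyl carbon moved the number beyond the scatter, whereas this exchange on the retained ring did not, so bromo and nitro read alike at this position. Nothing measured here explains why the two groups read alike.

With only these two substituents at this place, the compounds shown give no trend and leave open what an amine, a carboxylic acid or a longer chain would do there. They also leave open whether moving bromo or nitro to another carbon of the ring would change the number.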